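Chloro for methoxy on the aryl group of the shared core

The source may hold more compounds than are shown below. What is called first, only, known or untested is meant among the compounds shown, and "the series" means these compounds.

Measured so far:
compound 1, `COc1ccc(-c2nc3ccccn3c2Sc2ccccc2)cc1`: 83900 nM
compound 2, `Clc1ccc(Sc2c(-c3cccs3)nc3ccccn23)cc1`: 77300 nM

In a functional assay on SK-MEL-28 cells (Homo sapiens) for inhibition, read by MTT assay, with a stated time of 48 h (a higher number here means a weaker inhibitor, a lower number a stronger inhibitor), compound 1 gives 83900 nM, the higher of the two numbers, with compound 2 the nearest at 77300 nM; the gap between them lies within the scatter, so the two compounds read alike and neither is the stronger inhibitor on this evidence.

Compound 3, `Clc1ccc(-c2nc3ccccn3c2Sc2ccccc2)cc1`, is not yet measured. It differs from compound 1 in one place: chloro in place of methoxy on an aromatic carbon. Going by the values given here, no measured pair shows what this change does, and the two measured compounds sit close together, so there is no basis for a step in either direction beyond the scatter.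

Compound 3 is therefore expected to give a value near compound 1, with the step of a 1.2-fold lower number from compound 1 to compound 3 (0.08 log units; within the scatter) expected to stay inside the scatter. The estimate for compound 3 in this assay is 70000 nM, in the range 30000 nM to 160000 nM.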

Compound 3, half-maximal inhibitory concentration: 73100 nM
Compound 3: middle estimate off by 1.0-fold (0.02 log units), on the low side, and the stated range covers the measured number.
By their numbers in this assay, from the lowest: compounds 3, 2 and 1 (each within the scatter of the next).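

In this assay, chloro in place of methoxy on an aromatic carbon, para to a large group, gives a 1.1-fold lower number from compound 1 to compound 3 (0.06 log units; within the scatter) and forms the only pair shown that differs in one place. Compound 1 and compound 3 therefore read alike, so the 4-methoxyphenyl and 4-chlorophenyl groups cannot be told apart here, even though methoxy has a hydrogen-bond acceptor and chloro has none. Nothing at hand bears on why the two read alike.

Still open, as far as these compounds go, is whether any group on this aromatic carbon moves the number beyond the scatter; an amine or a carboxylic acid there would test a kind of group unlike methoxy and chloro. Nothing shown yet tells which part of the shared core, if any, this read-out responds to.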